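A few compounds are considered here, and "the series" means these few. Any claim that something is new, unique, unknown or untested is made for them only; others in the source may bear on it.

Measured so far:
- compound 1 `Cc1ccc(-c2csc(N3N=C(c4ccc(C)s4)CC3c3ccc(F)cc3)n2)cc1`: in an ADME assay on NIH3T3 cells (Mus musculus) for cytotoxicity, read by XTT assay, with a stated time of 24 h (a lower number here means a stronger inhibitor, a higher number a weaker inhibitor), compound 1 gives > 500 ug/mL, a limit of the assay and not a number.
- compound 2 `Cc1ccc(C2=NN(c3nc(-c4ccccc4)cs3)C(c3ccc(F)cc3)C2)s1`: in this assay compound 2 gives > 500 ug/mL, again a limit, not a number.
- compound 3 `Fc1ccc(C2CC(c3ccc(Cl)s3)=NN2c2nc(-c3ccccc3)cs2)cc1`: in this assay compound 3 gives > 500 ug/mL, also a limit.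

From compound 2 to compound 1 the change is methyl in place of hydrogen on an aromatic carbon; in this assay the step is a step that the two limits leave unreadable from compound 2 to compound 1. From compound 2 to compound 3 the change is chloro in place of methyl on an aromatic carbon; in this assay the step is a step that the two limits leave unreadable from compound 2 to compound 3. Both steps are unreadable in size, since the three values share (the limit of > 500 ug/mL in this assay, at which 3 of the 3 values shown sit).

Compound 4 `Cc1ccc(-c2csc(N3N=C(c4ccc(Cl)s4)CC3c3ccc(F)cc3)n2)cc1` has not yet been measured. It differs from compound 3 by methyl in place of hydrogen on an aromatic carbon. Going by the values given here, this is the same change as the one from compound 2 to compound 1; the two place descriptions agree word for word. The two cores differ as described by chloro in place of methyl on an aromatic carbon.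

In this assay the step from compound 3 to compound 4 is expected to be a step that the limit leaves unreadable from compound 3 to compound 4, set beside a step that the two limits leave unreadable from compound 2 to compound 1. The expectation rests on (the limit of > 500 ug/mL in this assay, at which 3 of the 3 values shown sit), which holds every measured value of the series, including compound 3 with > 500 ug/mL, so that a reported number for compound 4 would be unusual. Compound 4 is therefore estimated at 700 ug/mL, expected to fall between 400 ug/mL and 2000 ug/mL, most likely reported as a limit as well.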

Compound 4, half-maximal inhibitory concentration: > 500 ug/mL
Compound 4 gave a limit, no number; the forecaster's own chance of this, stated with the estimate: 85%; the middle value is on the limit's open side.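

In this assay compound 4 gives > 500 ug/mL, a limit and not a number. No new step can be read, neither from compound 3 to compound 4 nor from compound 1 to compound 4, and the series stays at one limit: the limit of > 500 ug/mL in this assay, at which 4 of the 4 values shown sit. The compounds shown leave open whether the methyl or the chloro change shifts the value in this assay at all; none of them gives a number there.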